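Amide-chain variation on the core of compound 1

The source may hold more compounds than are shown below. What is called first, only, known or untested is meant among the compounds shown, and "the series" means these compounds.

For the measured compounds named here, compound 1, `CCCC(=O)OCSc1ccccc1C(=O)NCCCCC(N)=O`, is one of three compounds measured in an ADME assay on CEM-SS cells (Homo sapiens) for cytotoxicity, read by XTT assay, with a stated time of 6 days (on this read-out lower numbers stand for higher toxicity in this test and higher numbers for lower toxicity in this test), where compound 1 gives 51.7 uM. This is the highest number of the three, but compound 2, `CCCC(=O)OCSc1ccccc1C(=O)Nc1ccccc1C(N)=O`, lies within the scatter of it with 50.1 uM, so the two cannot be ordered. Compound 3, `CCCC(=O)OC[Se]c1ccccc1C(=O)NCC(N)=O`, stands furthest away: in this assay compound 3 gives 6.8 uM, a gap beyond the scatter. Going by the values given here, compound 3 differs from compound 1 in more than one place, so the two values show only that compound 3 is the more toxic of that pair, not which part of the structure accounts for it.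

The unmeasured compound 4, `CCCC(=O)OCSc1ccccc1C(=O)NCC(=O)NC(C)(C)C`, is reached from compound 1 by a single change: (tert-butyl)carbamoyl in place of 3-carbamoylpropyl on a saturated chain carbon bound to an amide-type nitrogen. Among the compounds with values here, no measured pair that differs in this way is at hand, so no directly comparable step exists. The core of compound 1 is kept, and compound 2, with a different amide side chain, gives 50.1 uM within the scatter of compound 1. Compound 4 is therefore expected to stay close to compound 1, with a step of a 1.2-fold lower number from compound 1 to compound 4 (0.09 log units; within the scatter) that does not go beyond the scatter. Compound 4 is estimated at 42 uM in this assay, in the range 15 uM to 100 uM.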

Compound 4, half-maximal toxic concentration: 46.8 uM
For compound 4 the middle estimate is 1.1-fold (0.05 log units) below the measured one; the measured number falls inside the stated range.
By their numbers in this assay, from the lowest: compound 3; then compounds 4, 2 and 1 (each within the scatter of the next).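

For the compounds shown here, with a 1.1-fold lower number from compound 1 to compound 4 (0.04 log units; within the scatter), the exchange of 3-carbamoylpropyl (6 heavy atoms) for (tert-butyl)carbamoyl (7 heavy atoms) on a saturated chain carbon bound to an amide-type nitrogen gives the first comparison on the core of compound 1 in which only one place differs. In this assay, this position therefore tolerates this particular exchange without a change that can be told from the scatter, even though the terminal primary carbamoyl arrangement gives way to a chain ending in a tert-butyl group. Nothing measured here accounts for how small this step is.

The compounds shown leave open whether a carboxylic acid, an amine or a longer chain at this same place would carry the number in this assay beyond the scatter of compound 1. They also leave open which part of compound 3 goes with its gap from compound 1: no compound shown pairs selenium in place of sulfur with an otherwise unchanged side chain.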